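Cytotoxicity and a swap of the aromatic tail

The compounds below may be only part of what the source reports. "The series", "measured", "known", "first", "only" and "open" are said of these compounds alone.

Compound 1, `N/C(CC(O)c1cccc2ccccc12)=N\N=C\c1ccc(F)cc1F`, is tested in an ADME assay on L6 cells (Rattus norvegicus) for cytotoxicity, read by resazurin assay, with a stated time of 72 h (on this read-out higher numbers stand for weaker inhibition and lower numbers for stronger inhibition), where compound 1 gives 4200 nM. Compound 2, `N/C(CC(O)c1cccc2ccccc12)=N\N=C\c1ccco1`, keeps the same core but carries a furan-2-yl group in place of the 2,4-difluorophenyl; in this assay compound 2 gives 145000 nM. The step between them, a 35-fold lower number from compound 2 to compound 1 (1.54 log units; beyond the scatter), is the change (2,4-difluorophenyl in place of furan-2-yl on a carbon with a double bond to nitrogen), and it is a large one.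

Compound 3, `N/C(CC(O)c1ccc2ccccc2c1)=N\N=C\c1ccco1`, has a different core from compound 2; the difference between the two cores is not broken down here. In this assay compound 3 gives "not determined" (no result reported), so no number is available for it. Going by the values given here, compound 4, `N/C(CC(O)c1ccc2ccccc2c1)=N\N=C\c1ccc(F)cc1F`, is made from compound 3 by the same change, (2,4-difluorophenyl in place of furan-2-yl on a carbon with a double bond to nitrogen), the one that took compound 2 to compound 1.

Compound 4 shares its 2,4-difluorophenyl tail with compound 1, and is expected to come out near that compound. The expected value for compound 4 in this assay is 5000 nM, with a likely range from 1500 nM to 20000 nM. This expectation rests on compound 1, which gives 4200 nM, and on the step of a 35-fold lower number from compound 2 to compound 1 (1.54 log units; beyond the scatter).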

Compound 4, half-maximal inhibitory concentration: 93000 nM
Compound 4: middle estimate off by 19-fold (1.27 log units), on the low side; measured number above the stated range.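

With no number for compound 3 in this assay, the step from compound 3 to compound 4 cannot be read. The compounds shown leave open how large the change from furan-2-yl to 2,4-difluorophenyl is on the core of compound 4. No available evidence bears on this result.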